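Compound 1 at the Limit, a Larger Group Ahead

A few compounds are considered here, and "the series" means these few. Any claim that something is new, unique, unknown or untested is made for them only; others in the source may bear on it.

In an ADME assay on MDBK cells (Bos taurus) for cytotoxicity, read by MTT assay, with a stated time of 96 h (a lower number here means that less compound is tolerated, a higher number that more compound is tolerated), compound 1, `C/C(=N\O)c1ccc2[nH]c(-c3ccccc3)nc2c1`, gives > 100000 nM, which is a limit of the assay and not a number. Compound 2, `C/C(=N\O)c1ccc2[nH]c(-c3ccc(Cl)cc3)nc2c1`, gives 37000 nM in this assay. The exchange of hydrogen for chloro on an aromatic carbon amounts to an at least 2.7-fold lower number from compound 1 to compound 2 (0.43 log units; beyond the scatter). Compound 3, `C/C(=N\NC(N)=S)c1ccc2[nH]c(-c3ccccc3)nc2c1`, keeps the core of compound 1 but carries a new group on a double-bonded nitrogen: a group of 4 heavy atoms (1 carbon, 2 nitrogen, 1 sulfur; no ring) in place of one oxygen atom, on a double-bonded nitrogen. The chloro step is the only measured one and concerns a different change, so it offers only a rough guide to size. Taking compound 2 at 37000 nM as that guide, a move to a lower number of similar size is expected, an estimated at least 2.8-fold lower number from compound 1 to compound 3 (0.45 log units; beyond the scatter). For compound 3 the estimated value in this assay is 35000 nM, expected to fall between 9000 nM and 100000 nM.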

Compound 3, half-maximal cytotoxic concentration: 32000 nM
Estimate against measurement, compound 3: 1.1-fold (0.04 log units) above; the range from low to high includes it.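

Going by these compounds alone, until this point the only measured change sat on an aromatic carbon. Compound 3 shows that the place on the double-bonded nitrogen also matters in this assay, since a group of 4 heavy atoms in place of the hydroxy gives an at least 3.1-fold lower number from compound 1 to compound 3 (0.49 log units; beyond the scatter). The true size of this step stays unknown because compound 1 stands at a limit of the assay and not at a number: the limit of > 100000 nM in this assay, at which 1 of the 3 values shown sits.

The compounds shown leave open whether a simple amine or a methoxy group on this nitrogen would also lower the number, and whether the sulfur plays any part, as an oxygen in its place has yet to be compared. They also leave open how the chloro and the new group would act together on the shared core.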